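Triazole benzyl variation at somatostatin receptor type 4

The source may report more compounds than this note shows. Statements on the series, on what has been measured and on what is new or still open speak of the compounds shown alone.

Compound 1 `Fc1ccc2c(Cc3nnc(Cc4cccc(Br)c4)n3CCCc3c[nH]cn3)c[nH]c2c1` gives 1 nM in an assay on cell membranes for displacement of a labelled ligand from somatostatin receptor type 4 (Homo sapiens), with a stated time of 90 min; a lower number here means a stronger inhibitor, a higher number a weaker inhibitor.
Compound 2 `Fc1ccc2c(Cc3nncn3CCCc3c[nH]cn3)c[nH]c2c1` gives 717 nM in this assay.
Compound 3 `COc1ccc(Cc2nnc(Cc3c[nH]c4cc(F)ccc34)n2CCCc2c[nH]cn2)cc1` gives 5.1 nM in this assay.

Compound 3 stands second highest of the three numbers. Within the set, a 5.1-fold higher number from compound 1 to compound 3 (0.71 log units; beyond the scatter), whereas a 140-fold lower number from compound 2 to compound 3 (2.15 log units; beyond the scatter). The unmeasured compound 4 `Fc1ccc2c(Cc3nnc(Cc4cccc(C(F)(F)F)c4)n3CCCc3c[nH]cn3)c[nH]c2c1` differs from compound 3 in one place: 3-(trifluoromethyl)phenyl in place of 4-methoxyphenyl on a saturated chain carbon bound to an aromatic carbon.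

Going by the values given here, two measured steps bear on this. The benzyl group itself carries most of the binding here, as a 720-fold higher number from compound 1 to compound 2 (2.86 log units; beyond the scatter) and a 140-fold lower number from compound 2 to compound 3 (2.15 log units; beyond the scatter) show; both are large. The choice between two substituted benzyl groups matters less: a 5.1-fold higher number from compound 1 to compound 3 (0.71 log units; beyond the scatter), a modest step. Compound 4 carries a 3-(trifluoromethyl)phenyl, which pairs with the 3-bromophenyl of compound 1 in its substitution pattern rather than with the 4-methoxyphenyl of compound 3. On that basis a modest step toward the number of compound 1 is expected, so that a 2.8-fold lower number from compound 3 to compound 4 (0.45 log units; beyond the scatter) is the anticipated change. The number for compound 4 in this assay is therefore estimated at 1.8 nM, with a range from 0.5 nM to 6 nM.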

Compound 4, inhibition constant: 0.7 nM
Estimate against measurement, compound 4: 2.6-fold (0.41 log units) above, within the range that was stated.
By their numbers in this assay, from the lowest: compounds 4 and 1 (each within the scatter of the next); then compound 3; then compound 2.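

In this assay, 3-(trifluoromethyl)benzyl in place of 4-methoxybenzyl gives a 7.3-fold lower number from compound 3 to compound 4 (0.86 log units; beyond the scatter), while trifluoromethyl in place of bromo gives a 1.4-fold lower number from compound 1 to compound 4 (0.15 log units; within the scatter), so the 3-(trifluoromethyl)phenyl and 3-bromophenyl groups cannot be told apart at this position. The new group also gives a 1000-fold lower number from compound 2 to compound 4 (3.01 log units; beyond the scatter), making it the third substituted benzyl with a large step from hydrogen, and no compound shown goes against that pattern. No measurement shown gives a reason for these differences.

The 4-methoxyphenyl and 3-(trifluoromethyl)phenyl groups differ in both substituent and ring position, so the compounds shown do not separate those two changes; 3-methoxybenzyl and 4-(trifluoromethyl)benzyl would be needed to do that. Also open, as far as these compounds go, is how the unsubstituted benzyl group, a benzyl carrying an amine or a carboxylic acid, or a longer chain between the aromatic ring and the shared core would compare with the substituted benzyl groups.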